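Fluoro for isopropylcarbamoyl on compound 1

The source may report more compounds than this note shows. Statements on the series, on what has been measured and on what is new or still open speak of the compounds shown alone.

For the measured compounds named here, in a functional assay on Huh-7 cells (Homo sapiens) for antiproliferative activity, read by CCK-8 assay, with a stated time of 72 h (on this read-out higher numbers stand for weaker inhibition of growth and lower numbers for stronger inhibition of growth), compound 1 (`CCC1C(=O)N(C)c2cnc(-n3ccc4cc(C(=O)NC(C)C)ccc43)nc2N1c1ccn(C)n1`) gives 6740 nM, the highest of the three numbers measured so far. Compound 3 (`CC[C@@H]1C(=O)N(C)c2cnc(Nc3ccc(S(=O)(=O)Nc4ccccc4)cc3)nc2N1C1CCCC1`) gives 2790 nM, and compound 2 (`CCCCNS(=O)(=O)c1ccc(Nc2ncc3c(n2)N(C2CCCC2)[C@H](CC)C(=O)N3C)cc1`) gives 225 nM.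

Compound 4 (`CCC1C(=O)N(C)c2cnc(-n3ccc4cc(F)ccc43)nc2N1c1ccn(C)n1`) has fluoro in place of isopropylcarbamoyl on an aromatic carbon.

Going by the values given here, only one measured step is available: a 12-fold higher number from compound 2 to compound 3 (1.09 log units; beyond the scatter), with phenyl in place of butyl on a sulfonamide nitrogen. That change lies at another place, on compounds with a different core from compound 1, so it gives no direction for this one. Among the compounds with values here, it shows only that one substituent change can produce a large shift in this assay. Within the data shown here, no measured step covers the loss of isopropylcarbamoyl, so the expectation is weakly grounded, and a large shift either way cannot be ruled out.

The estimated change is small, toward a slightly higher number: a 1.2-fold higher number from compound 1 to compound 4 (0.07 log units; within the scatter). For compound 4 the expected value is 8000 nM, within an estimated range of 2500 nM to 25000 nM.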

Compound 4, concentration for 50% growth inhibition: "not active" (no number reported)
No number was reported for compound 4, so the estimate cannot be set against anything.
By their numbers in this assay, from the lowest: compound 2; then compound 3; then compound 1.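

In this assay, for the compounds shown here, compound 4 is reported as not active, with no number, so no step from compound 1 to compound 4 can be read. No evidence bears on this result. The compounds shown leave open how much growth inhibition changes with fluoro in place of isopropylcarbamoyl on the core of compound 1.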